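Thiophene for naphthalene on an acetylated glycosyl triazole oxindole

The compounds below may be only part of what the source reports. "The series", "measured", "known", "first", "only" and "open" are said of these compounds alone.

Compounds measured in a functional assay on DU-145 cells (Homo sapiens) for cytotoxicity, read by sulforhodamine B assay, with a stated time of 48 h; a higher number here means a weaker inhibitor, a lower number a stronger inhibitor:
compound 1, `CC(=O)OC[C@H]1O[C@@H](n2cc(CN3C(=O)/C(=C/c4ccc(C)cc4)c4ccccc43)nn2)[C@H](OC(C)=O)[C@@H](OC(C)=O)[C@@H]1OC(C)=O`, gives 9300 nM
compound 2, `CC(=O)OC[C@H]1O[C@@H](n2cc(CN3C(=O)/C(=C/C=C/c4ccccc4)c4ccccc43)nn2)[C@H](OC(C)=O)[C@@H](OC(C)=O)[C@@H]1OC(C)=O`, gives 17100 nM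
compound 3, `CC(=O)OC[C@H]1O[C@@H](n2cc(CN3C(=O)/C(=C/c4ccc5ccccc5c4)c4ccccc43)nn2)[C@H](OC(C)=O)[C@@H](OC(C)=O)[C@@H]1OC(C)=O`, gives 43700 nM

Compound 3 stands at the high end of these three numbers, and both of its steps from the others are beyond the scatter, so on this set it is the weakest inhibitor in this assay: a 4.7-fold higher number from compound 1 to compound 3 (0.67 log units; beyond the scatter) and a 2.6-fold higher number from compound 2 to compound 3 (0.41 log units; beyond the scatter). Compound 4, `CC(=O)OC[C@H]1O[C@@H](n2cc(CN3C(=O)/C(=C/c4cccs4)c4ccccc43)nn2)[C@H](OC(C)=O)[C@@H](OC(C)=O)[C@@H]1OC(C)=O`, differs from compound 3 in one place: thiophen-2-yl in place of naphthalen-2-yl on a double-bonded chain carbon bound to a double-bonded ring carbon. For the measured compounds named here, no measured step brings the thiophen-2-yl group in, so the only bearing evidence is the pair of steps in which naphthalen-2-yl entered, both modest and both toward a higher number. Reversing that entry is therefore expected to move the number back down by a modest amount, and the step from compound 3 to compound 4 is estimated as a 3.6-fold lower number from compound 3 to compound 4 (0.56 log units; beyond the scatter). Compound 4 is expected to give about 12000 nM in this assay, with a range from 4500 nM to 32000 nM.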

Compound 4, half-maximal inhibitory concentration: 23400 nM
Estimate against measurement, compound 4: 2.0-fold (0.29 log units) below; low and high end bracket the measured number.
By their numbers in this assay, from the lowest: compounds 1, 2, 4 and 3 (each within the scatter of the next, the first and the last beyond it).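

In this assay the one five-membered aromatic ring of thiophen-2-yl, taking the place of the two six-membered aromatic rings of naphthalen-2-yl, gives a 1.9-fold lower number from compound 3 to compound 4 (0.27 log units; within the scatter) and so compound 3 no longer stands clear of every other compound in the set. Thiophen-2-yl also gives a 1.4-fold higher number from compound 2 to compound 4 (0.14 log units; within the scatter) against 2-phenylethenyl and a 2.5-fold higher number from compound 1 to compound 4 (0.40 log units; beyond the scatter) against 4-methylphenyl and this leaves compound 1 as the only compound separated beyond the scatter from both compound 3 and compound 4. No measurement at hand explains these differences.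

The compounds shown leave open how furan-2-yl, or a phenyl ring carrying an amine or a carboxylic acid, would read at this place. They also leave open whether thiophen-2-yl would hold its standing with free hydroxyl groups in place of the acetyl groups.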